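The compounds below may be only part of what the source reports. "The series", "measured", "known", "first", "only" and "open" are said of these compounds alone.

Measured so far in a physicochemical assay for lipophilicity, read by LC-MS; on this read-out lower numbers stand for lower lipophilicity and higher numbers for higher lipophilicity:
- Compound 1 `FC(F)(F)c1nccc(N[C@H]2CC[C@@H](Nc3ncnc4sccc34)CC2)n1`: 2.9
- Compound 2 `FC(F)(F)c1nccc(N[C@H]2CC[C@@H](Nc3ccc4ncc(Cl)n4n3)CC2)n1`: 4.3
- Compound 3 `FC(F)(F)c1nccc(N[C@H]2CC[C@@H](Nc3ccc4nnc(Br)n4n3)CC2)n1`: 2.9

On this assay, compound 3 stands level with compound 1, with no difference at the digits shown. Compound 2 lies higher than both, beyond the scatter.

The next compound to be read is compound 4 `FC(F)(F)c1nccc(N[C@H]2CC[C@@H](Nc3ccc4nnc(C(F)(F)F)n4n3)CC2)n1`, which has trifluoromethyl in place of bromo on an aromatic carbon. Among the compounds with values here, no measured pair differs in one place only, so the series offers no direct guide to this change, and the expectation remains a judgement. The expected step is a number 0.20 log units higher from compound 3 to compound 4 (within the scatter), small and upward, within the scatter. For compound 4 the estimated value is 3.1, with an expected range of 2.7 to 3.6.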

Compound 4, distribution coefficient: 3.8
Beside the measured number, compound 4's estimate is 0.70 log units below it, outside the stated range (above it).
By their numbers in this assay, from the lowest: compounds 1 and 3 (each within the scatter of the next); then compound 4; then compound 2.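

In this assay, within the data shown here, trifluoromethyl in place of bromo on an aromatic carbon between two ring nitrogen atoms gives the first single-place step, a number 0.90 log units higher from compound 3 to compound 4 (beyond the scatter), and this lies beyond the scatter. The read-out at this position therefore depends on the group it carries. Nothing at hand accounts for the size of this step.

Where a methyl, a nitrile or an amine would fall at this position remains open. Going by these compounds, with a single pair, it is also open whether this step would hold on another core.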